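Three Analogues at the Assay Limit and a Fourth

The source may hold more compounds than are shown below. What is called first, only, known or untested is meant among the compounds shown, and "the series" means these compounds.

Compound 1 `COC(=O)[C@H](CCSC)NC(=O)c1ccc(NCc2cncn2Cc2cccc(C#N)c2)cc1-c1ccccc1` — a functional assay on NIH3T3 cells (Mus musculus); a lower number here means that less compound is needed, a higher number that more compound is needed for the effect: > 10 uM
Compound 2 `CSCC[C@H](NC(=O)c1ccc(NCc2cncn2Cc2cccc(C)c2)cc1-c1ccccc1)C(=O)O` — this assay: > 10 uM
Compound 3 `CSCC[C@H](NC(=O)c1ccc(NCc2cncn2Cc2ccccc2Cl)cc1-c1ccccc1)C(=O)O` — this assay: > 10 uM

The three measured compounds share one core and differ in the benzyl group on a saturated chain carbon bound to an aromatic nitrogen, or in the ester against the free acid. In this assay compound 3 gives only a limit of the assay, not a number. The same holds for compound 2, whose value is likewise a limit. Compound 1 also returns a limit in this assay. Accordingly (the limit of > 10 uM in this assay, at which 3 of the 3 values shown sit), and the one single-point step, a step that the two limits leave unreadable from compound 2 to compound 3, cannot be read in size or direction.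

Compound 4 `CSCC[C@H](NC(=O)c1ccc(NCc2cncn2Cc2cccc(C#N)c2)cc1-c1ccccc1)C(=O)O` is not yet measured. It differs from compound 3 by 3-cyanophenyl in place of 2-chlorophenyl on a saturated chain carbon bound to an aromatic nitrogen. Among the measured compounds shown here, compound 1 carries the same 3-cyanobenzyl group as compound 4 and sits at the limit, and compound 3 sits at the limit, so no measured step gives a direction. Compound 4 is therefore expected to remain at or near the limit, with an expected value of 20 uM, in the range 5 uM to 100 uM. The step that the limit leaves unreadable from compound 3 to compound 4 is thus estimated to be unreadable against the limit.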

Compound 4, concentration for half-maximal effect: > 10 uM
Compound 4: only a limit was reported (the forecaster's own chance of this, stated with the estimate: 85%); the middle value is on the limit's open side.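

Compound 4 gives > 10 uM in this assay, which is a limit and not a number. Its steps from compound 1, compound 2 and compound 3 cannot be read: the limit of > 10 uM in this assay, at which 4 of the 4 values shown sit.

The compounds shown leave open where each true value lies and whether the benzyl group or the ester against the free acid alters it.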